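An Amino Group Added to a Weakly Cytotoxic Core

The compounds below may be only part of what the source reports. "The series", "measured", "known", "first", "only" and "open" are said of these compounds alone.

Four close relatives are compared for their power to hold back the growth of a liver cancer cell line in a functional assay on Hep 3B2 cells (Homo sapiens) for cytotoxicity, read by sulforhodamine B assay, with a stated time of 48 h; a lower number here means a stronger inhibitor, a higher number a weaker inhibitor. Compound 1 has the structure `CCn1cc(-c2nc3ccccc3[nH]2)c(=O)c2cc(F)c(N3CCNCC3)cc21`. In this assay compound 1 gives only a limit, > 10000 nM, not a number. Compound 2, `CCn1cc(-c2nc3ccccc3[nH]2)c(=O)c2cc(F)c(N3CCNCC3)nc21`, carries a different core; the difference between the two cores is not broken down here. In this assay, among the compounds with values here, compound 2 gives 7800 nM, the only full number among the three measured compounds. Compound 3, `CCn1cc(-c2nc3ccc(N)cc3[nH]2)c(=O)c2cc(F)c(N3CCNCC3)cc21`, arises from compound 1 by the change (amino in place of hydrogen on an aromatic carbon). In this assay compound 3 also gives a limit, > 10000 nM. Since both ends sit at the limit of > 10000 nM in this assay, at which 2 of the 3 values shown sit, the outcome is a step that the two limits leave unreadable from compound 1 to compound 3, so whether the amino group helped or hurt cannot be read.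

Compound 4, `CCn1cc(-c2nc3ccc(N)cc3[nH]2)c(=O)c2cc(F)c(N3CCNCC3)nc21`, is the unmeasured partner: it comes from compound 2 by amino in place of hydrogen on an aromatic carbon, the same change as from compound 1 to compound 3, made at the same kind of place. With the earlier instance unreadable, the expectation rests on the starting point alone, namely compound 2 with 7800 nM. On that basis the expected step is a 1.0-fold higher number from compound 2 to compound 4 (0.01 log units; within the scatter), one that stays within the usual scatter. Compound 4 is therefore estimated at 8000 nM, between 3000 nM and 20000 nM, with a real chance that this assay returns only a limit.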

Compound 4, half-maximal inhibitory concentration: > 10000 nM
Compound 4 gave a limit, no number; the forecaster's own chance of this, stated with the estimate: 45%; middle value at least 1.2-fold (0.09 log units) away from the limit.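

Placing the amino group on the core of compound 2 brought no gain in this assay, giving an at least 1.2-fold higher number from compound 2 to compound 4 (0.10 log units; that floor lies within the scatter); this floor alone does not establish a real loss, and compound 4 gives > 10000 nM, which is a limit and not a number. The same change on the core of compound 1 cannot be read, so this series offers no two sizes to set side by side, and it does not show that the change acts alike on both cores. The true size of the new step and any difference between the cores stay unknown because most of the series sits at one limit: the limit of > 10000 nM in this assay, at which 3 of the 4 values shown sit.

The compounds shown leave open whether any other group on that same aromatic carbon, such as a methoxy group, a nitro group or a carboxylic acid, would give a clear number rather than a limit. They also leave open whether a group of that kind would behave the same way on both cores, since only the amino group and hydrogen are compared at that place here.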